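This account rests on a few compounds, and the source may have more. Where it says the series, first, only, none or still open, it means among the compounds named here.

Series values in a physicochemical assay for lipophilicity, at pH 7.4; on this read-out lower numbers stand for lower lipophilicity and higher numbers for higher lipophilicity:
- compound 1 `CCc1ccc(N(CC(C)C)S(=O)(=O)c2ccc3c(c2)C(=O)CC(C2CCN(S(=O)(=O)C4CCCC4)CC2)O3)cc1`: 4.75
- compound 2 `CCc1ccc(N(CC(C)C)S(=O)(=O)c2ccc3c(c2)C(=O)CC(C2CCN(C(=O)C4CCCC4)CC2)O3)cc1`: 5.13

Compound 2 holds the higher of the two numbers in this assay, at 5.13. Compound 3 `CCc1ccc(N(CC(C)C)S(=O)(=O)c2ccc3c(c2)C(=O)CC(C2CCN(C(=O)OC(C)(C)C)CC2)O3)cc1` has tert-butoxy in place of cyclopentyl on a carbonyl carbon. Going by the values given here, the sole measured step, a number 0.38 log units higher from compound 1 to compound 2 (beyond the scatter), was modest and changed a different group, so it bears on this change only loosely. Among the compounds with values here, no measured step covers this exchange. A small upward step in this assay is expected, and it may not exceed the scatter. The estimated step is a number 0.17 log units higher from compound 2 to compound 3 (within the scatter). Compound 3 is expected at 5.3, within 4.9 to 5.7.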

Compound 3, distribution coefficient: 5.1
Compound 3: middle estimate off by 0.20 log units, on the high side, within the range that was stated.
By their numbers in this assay, from the lowest: compound 1; then compounds 3 and 2 (each within the scatter of the next).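

In this assay tert-butoxy on the carbonyl carbon reads level with cyclopentyl (a number 0.03 log units lower from compound 2 to compound 3 (within the scatter)), so at this position a group with no ring and one hydrogen-bond acceptor gives no resolved difference from a five-membered carbon ring. Tert-butoxycarbonyl in place of cyclopentylsulfonyl on the amine nitrogen in a ring gives a step (a number 0.35 log units higher from compound 1 to compound 3 (beyond the scatter)) of about the size seen with cyclopentylcarbonyl (a number 0.38 log units higher from compound 1 to compound 2 (beyond the scatter)). No measurement on hand accounts for these steps. From the compounds shown here alone, whether an amine or a methoxy group on the same carbonyl carbon would also read level stays open.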